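Removing an Acetyl Group from a Shared Core

The compounds below may be only part of what the source reports. "The series", "measured", "known", "first", "only" and "open" are said of these compounds alone.

Two measured compounds share one core. Compound 1 `N#Cc1c(Nc2ccc(C(F)(F)F)cc2)sc2ccccc12` carries a trifluoromethyl group and a hydrogen on its nitrogen. Compound 2 `CC(=O)N(c1ccc(O)cc1)c1sc2ccccc2c1C#N` carries a hydroxyl group in place of the trifluoromethyl and an acetyl on the nitrogen. In a functional assay on HUVEC cells (Homo sapiens), read by fluorescence and microscopy, with a stated time of 6 h, tested at 250 nM (on this read-out higher numbers stand for a weaker effect at the one concentration tested and lower numbers for a stronger effect), compound 1 gives 65%, and compound 2 gives 59%. Compound 2 shows the lower of the two numbers, yet the gap to compound 1 lies within the usual scatter, so the two readings cannot be told apart. Compound 3 `N#Cc1c(Nc2ccc(O)cc2)sc2ccccc12` keeps the hydroxyl group of compound 2 and changes one place: hydrogen in place of acetyl on a nitrogen on an aromatic ring. Within the data shown here, no measured pair shows what this change does, so no step beyond the scatter is expected in either direction. The step this estimate means, a number 1 percentage points higher from compound 2 to compound 3 (within the scatter), is expected to be small. Compound 3 is estimated at 60%, with a range of 40% to 80%.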

Compound 3, a percentage reported as activity, at one concentration (the size of the read-out at that concentration, not a potency): 2%
Beside the measured number, compound 3's estimate is 58 percentage points above it; measured number outside the range, below it.
By their numbers in this assay, from the lowest: compound 3; then compounds 2 and 1 (each within the scatter of the next).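

In this assay, replacing the acetyl on the nitrogen on an aromatic ring with hydrogen gives a number 57 percentage points lower from compound 2 to compound 3 (beyond the scatter), so this position strongly affects the read-out when the hydroxy group is present. Placing hydroxy in place of trifluoromethyl on an aromatic carbon, with hydrogen kept on the nitrogen, gives a number 63 percentage points lower from compound 1 to compound 3 (beyond the scatter), which shows that the strong effect in compound 3 depends on both features together, something compound 1 and compound 2 could not reveal because they differ in two places. Nothing in the available data explains why either change has so large an effect. The compounds shown leave open whether a methyl on the nitrogen would behave like hydrogen or like acetyl. They also leave open whether an amine or a carboxylic acid in place of the hydroxy group would keep the effect.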